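Shrinking the Ring on Compound 1: Piperidine to Pyrrolidine

The compounds below may be only part of what the source reports. "The series", "measured", "known", "first", "only" and "open" are said of these compounds alone.

Compound 1 `O=c1cc(CSC(=S)N2CCCCC2)oc2cc(Cl)ccc12` gives 1600 nM in a functional assay on HEp-2 cells (Homo sapiens) for antiproliferative activity, read by MTT assay, with a stated time of 72 h (a higher number here means a weaker inhibitor, a lower number a stronger inhibitor), the lowest of the three numbers measured. Compound 3 `O=c1cc(CSC(=S)N2CCCCC2)oc2ccccc12` gives 12000 nM; the step of a 7.5-fold higher number from compound 1 to compound 3 (0.88 log units; beyond the scatter) goes with hydrogen in place of chloro on an aromatic carbon. Within the data shown here, compound 2 `O=c1cc(CSC(=S)N2CCN(c3ccccc3)CC2)oc2cc(Cl)ccc12` gives 15900 nM, a higher number than compound 1, and no single-point step connects them. Compound 4 `O=c1cc(CSC(=S)N2CCCC2)oc2cc(Cl)ccc12` differs from compound 1 by pyrrolidin-1-yl in place of piperidin-1-yl on a thiocarbonyl carbon, a change of ring size on the same amine. Among the measured compounds shown here, no measured step bears on this change: the one measured step concerns the chloro group, not the ring. The change is expected to give a step of a 1.6-fold higher number from compound 1 to compound 4 (0.19 log units; within the scatter), not beyond the scatter. Compound 4 is therefore estimated at 2500 nM, within 800 nM to 8000 nM.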

Compound 4, half-maximal inhibitory concentration: > 40000 nM
Compound 4: a limit, no number; the forecaster's own chance of this, stated with the estimate: 5%; at least 16-fold (1.20 log units) between middle value and limit.
By their numbers in this assay, from the lowest: compound 1; then compounds 3 and 2 (each within the scatter of the next). At a limit, above all of these: compound 4.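

In this assay, among these compounds, the step of an at least 25-fold higher number from compound 1 to compound 4 (1.39 log units; beyond the scatter) goes with pyrrolidin-1-yl in place of piperidin-1-yl on a thiocarbonyl carbon, so the amine ring matters here, whereas the only earlier step concerned the chloro group. Compound 4 gives a limit, not a number: the limit of > 40000 nM in this assay, at which 1 of the 4 values shown sits.

A change of ring size alone is thus enough to move the result beyond the scatter, though how far beyond cannot be read. The compounds shown leave open how a seven-membered azepane ring or an open-chain diethylamino group would behave at this place on the same core.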